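The source may report more compounds than this note shows. Statements on the series, on what has been measured and on what is new or still open speak of the compounds shown alone.

Measured so far:
compound 1 `C=CC(=O)Nc1cccc(NC(=O)CSc2nc(Nc3ccccc3F)c3ccccc3n2)c1` — 9340 nM
compound 2 `C=CC(=O)Nc1cccc(NC(=O)CSc2nc(Nc3ccccc3Cl)c3ccccc3n2)c1` — 14400 nM
compound 3 `C=CC(=O)Nc1cccc(NC(=O)CSc2nc(Nc3ccccc3Br)c3ccccc3n2)c1` — 17100 nM

In a functional assay on PC-3 cells (Homo sapiens) for inhibition, read by MTT assay, with a stated time of 72 h (on this read-out higher numbers stand for weaker inhibition and lower numbers for stronger inhibition), compound 3 carries the highest number of the three, yet the steps of a 1.2-fold higher number from compound 2 to compound 3 (0.07 log units; within the scatter) and a 1.8-fold higher number from compound 1 to compound 3 (0.26 log units; within the scatter) both fall within the scatter, so no order among the three is claimed. Compound 4 `C=CC(=O)Nc1cccc(NC(=O)CSc2nc(Nc3ccccc3C)c3ccccc3n2)c1` differs from compound 3 by methyl in place of bromo on an aromatic carbon. Within the data shown here, no measured step involves a methyl; the steps that bear on this change are the three halogen swaps at the same place, a 1.5-fold higher number from compound 1 to compound 2 (0.19 log units; within the scatter), a 1.8-fold higher number from compound 1 to compound 3 (0.26 log units; within the scatter) and a 1.2-fold higher number from compound 2 to compound 3 (0.07 log units; within the scatter), every one within the scatter. A change at this carbon has so far left the read-out within the scatter, and the expected step for compound 4 is estimated as a 1.2-fold lower number from compound 3 to compound 4 (0.09 log units; within the scatter). Compound 4 is estimated at 14000 nM, with a range from 6000 nM to 35000 nM.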

Compound 4, half-maximal inhibitory concentration: 23200 nM
For compound 4 the middle estimate is 1.7-fold (0.22 log units) below the measured one; the range from low to high includes it.
By their numbers in this assay, from the lowest: compounds 1, 2, 3 and 4 (each within the scatter of the next, the first and the last beyond it).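

In this assay, among these compounds, the swap of fluoro for methyl on this aromatic carbon gives the first step at this position beyond the scatter (a 2.5-fold higher number from compound 1 to compound 4 (0.40 log units; beyond the scatter)), and a modest one. The other two steps to methyl stay within it (a 1.4-fold higher number from compound 3 to compound 4 (0.13 log units; within the scatter) and a 1.6-fold higher number from compound 2 to compound 4 (0.21 log units; within the scatter)), so only compound 1 and compound 4 separate. Nothing available gives a reason for this step.

Open, from the compounds shown here alone, is whether an amine, a methoxy group or a carboxylic acid on this carbon would move the read-out further than methyl does.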